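Changing the Amide Substituent: Expectation for Compound 4

The source may hold more compounds than are shown below. What is called first, only, known or untested is meant among the compounds shown, and "the series" means these compounds.

Measured compounds:
- compound 1, `CCC[C@@H]1CN[C@H](C(=O)N2CCC[C@H]2C#N)C1`: 50%
- compound 2, `N#C[C@@H]1CCCN1C(=O)[C@@H]1C[C@H](C(=O)N2CCCCCCC2)CN1`: 63%
- compound 3, `CCN(CC)C(=O)[C@@H]1CN[C@H](C(=O)N2CCC[C@H]2C#N)C1`: 43%

In an assay on the whole organism (plasma, strain Sprague-Dawley) for inhibition of Dipeptidyl peptidase 4 (Rattus norvegicus), with a stated time of 6 h, at a dose of 1 mg/kg by the oral route (a lower number here means less inhibition, a higher number more inhibition at the dose given (going by the name of the read-out)), compound 3 gives the smallest of the three numbers, though one of the two gaps that separate it from the others is a number 7 percentage points lower from compound 1 to compound 3 (within the scatter), and the other is a number 20 percentage points lower from compound 2 to compound 3 (beyond the scatter). The unmeasured compound 4, `CCCNC(=O)[C@@H]1CN[C@H](C(=O)N2CCC[C@H]2C#N)C1`, differs from compound 3 in one place: propylamino in place of diethylamino on a carbonyl carbon.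

Within the data shown here, two measured steps touch this position. The step from propyl to diethylcarbamoyl was a number 7 percentage points lower from compound 1 to compound 3 (within the scatter), while swapping the eight-membered ring amide for the diethyl amide was a number 20 percentage points lower from compound 2 to compound 3 (beyond the scatter). Among the measured compounds shown here, neither step is the same as replacing diethylamino with propylamino, and no measured pair shows a secondary amide at this position, so only a rough guide exists. Since both changes in the amide part moved the number modestly or not at all, compound 4 is expected to stay close to compound 3, with a step of a number 2 percentage points higher from compound 3 to compound 4 (within the scatter), which is within the scatter. Compound 4 is therefore estimated at 45%, with a likely range from 25% to 65%.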

Compound 4, a percentage reported as inhibition, in the whole organism at one dose (the size of the read-out at that dose, not a potency): 59%
The estimate for compound 4 lay 14 percentage points below the measured number; the range from low to high includes it.
By their numbers in this assay, from the lowest: compounds 3, 1, 4 and 2 (each within the scatter of the next, the first and the last beyond it).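

In this assay, propylamino in place of diethylamino on the carbonyl carbon gives a number 16 percentage points higher from compound 3 to compound 4 (beyond the scatter), so this amide is sensitive to a small change in its nitrogen substituent, one that also brings in an amide hydrogen. The other two steps, a number 4 percentage points lower from compound 2 to compound 4 (within the scatter) and a number 9 percentage points higher from compound 1 to compound 4 (within the scatter), show that the gap to the eight-membered ring amide seen with diethylcarbamoyl closes to within the scatter with propylcarbamoyl. Nothing shown gives a measured reason for these steps.

Going by these compounds, it remains open whether the higher number goes with the amide hydrogen or with the shape of the chain, a question that methylpropylamino, which keeps the propyl chain but has no amide hydrogen, could separate. On these data alone, how a longer chain such as hexylamino, or a carboxylic acid in place of the amide, would behave here also remains open.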